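From 4-methylpiperidin-1-yl to acetamido at compound 3

The source may report more compounds than this note shows. Statements on the series, on what has been measured and on what is new or still open speak of the compounds shown alone.

Measured so far in a functional assay on NCI-H1975 cells (Homo sapiens) for cytotoxicity, read by MTT assay, with a stated time of 72 h (a higher number here means a weaker inhibitor, a lower number a stronger inhibitor), are three compounds.
- Compound 1 (`CC(C)n1c(Nc2ccccc2)nc2cnc(Nc3ccc(N4CCN(C)CC4)cc3)nc21`) gives 960 nM 
- Compound 2 (`Cc1cc(C)cc(-n2c(Nc3ccccc3)nc3cnc(Nc4ccc(N5CCN(C)CC5)cc4)nc32)c1`) gives 1910 nM 
- Compound 3 (`CC1CCN(c2ccc(Nc3ncc4nc(Nc5ccccc5)n(C5CCCC5)c4n3)cc2)CC1`) gives 9800 nM 

Compound 3 has the highest number of the three and is the weakest inhibitor here, beyond the scatter from both others. Compound 4 (`CC(=O)Nc1ccc(Nc2ncc3nc(Nc4ccccc4)n(C4CCCC4)c3n2)cc1`) differs from compound 3 in one place (acetamido in place of 4-methylpiperidin-1-yl on an aromatic carbon) on an aromatic carbon of a six-membered aromatic ring of carbon only. Among the compounds with values here, the only measured step is a 2.0-fold higher number from compound 1 to compound 2 (0.30 log units; within the scatter) and it concerns the group on an aromatic nitrogen, not this place. Within the data shown here, no measured step isolates a change at this aromatic carbon, so the data offer no direct guide to size or direction. A shift beyond the scatter is therefore not expected, though a wide margin is needed. The estimated step is a 1.1-fold lower number from compound 3 to compound 4 (0.04 log units; within the scatter) and this amounts to no expected change. For compound 4 the expected value is 9000 nM with an estimated range from 3000 nM to 30000 nM in this assay.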

Compound 4, half-maximal inhibitory concentration: 1210 nM
The estimate for compound 4 lay 7.4-fold (0.87 log units) above the measured number; measured number outside the range, below it.
By their numbers in this assay, from the lowest: compounds 1, 4 and 2 (each within the scatter of the next); then compound 3.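

In this assay, the group on this aromatic carbon proves able to move the result, with acetamido in place of 4-methylpiperidin-1-yl giving an 8.1-fold lower number from compound 3 to compound 4 (0.91 log units; beyond the scatter). The only earlier step concerned the group on an aromatic nitrogen and stayed within the scatter, so this is the first change shown that makes a clear difference, here towards a stronger inhibitor. Nothing measured here explains the gain.

The swap changes several things at once: the ring goes, the heavy-atom count falls, and a hydrogen-bond donor enters, so these compounds cannot show which of these matters. Going by these compounds, it also remains open how a plain amine, a carboxylic acid or a longer amide chain on this same carbon would compare with acetamido.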